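The compounds below may be only part of what the source reports. "The series", "measured", "known", "first", "only" and "open" are said of these compounds alone.

Measured in an ADME assay on Huh-7 cells (Homo sapiens) for cytotoxicity, read by MTT assay, with a stated time of 72 h; a lower number here means that less compound is tolerated, a higher number that more compound is tolerated:
- Compound 1 `Cc1cc(=O)oc2cc(OCc3cn(-c4ccccc4Cl)nn3)ccc12`: > 100 ug/mL (a limit)
- Compound 2 `Cc1ccc(-n2cc(COc3ccc4c(C)cc(=O)oc4c3)nn2)c(Cl)c1`: > 100 ug/mL (a limit)

Compound 2 gives > 100 ug/mL, which is a limit of the assay and not a number. Both measured compounds sit at the same point, (the limit of > 100 ug/mL in this assay, at which 2 of the 2 values shown sit), so compound 2 cannot be ranked against compound 1.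

The next compound is compound 3 `Cc1cc(=O)oc2cc(OCc3cn(Cc4ccccc4)nn3)ccc12`, which carries benzyl in place of 2-chloro-4-methylphenyl on an aromatic nitrogen. Among the measured compounds shown here, only one measured step bears on this change, a step that the two limits leave unreadable from compound 1 to compound 2, and it offers no size to carry over. It also involves a smaller change on the same aromatic ring. With no measured size to go on, no shift beyond the usual scatter is expected in this assay, and the assay may well report another limit. The expected step is a step that the limit leaves unreadable from compound 2 to compound 3.

For compound 3 the estimate is 130 ug/mL, with an expected range from 60 ug/mL to 300 ug/mL.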

Compound 3, half-maximal cytotoxic concentration: > 100 ug/mL
Compound 3 was reported as a limit; the forecaster's own chance of this, stated with the estimate: 75%; the middle value does not contradict the limit.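

Among the compounds shown here, compound 3 gives > 100 ug/mL in this assay and this is a limit of the assay, not a number, so no step linking compound 1, compound 2 and compound 3 can be read: the limit of > 100 ug/mL in this assay, at which 3 of the 3 values shown sit. The compounds shown leave open how much of each is tolerated, and whether changing the group on the aromatic nitrogen alters that.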